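Cytotoxicity on fibroblasts: para-substituent swap on the hydrazone aryl

The compounds below may be only part of what the source reports. "The series", "measured", "known", "first", "only" and "open" are said of these compounds alone.

Measured so far:
compound 1 `Cn1nnnc1SCC(=O)N/N=C/c1ccccc1` — 9700000 nM
compound 2 `CN(C)c1ccc(/C=N/NC(=O)CSc2nnnn2C)cc1` — 316000 nM

Compound 2 gives the lowest of the two numbers in an ADME assay on NIH3T3 cells (Mus musculus) for cytotoxicity, read by XTT assay, with a stated time of 24 h; a higher number here means a weaker inhibitor, a lower number a stronger inhibitor; compound 1 is the nearest point, a step of a 31-fold lower number from compound 1 to compound 2 (1.49 log units; beyond the scatter) higher, well beyond the scatter. Compound 3 `Cn1nnnc1SCC(=O)N/N=C/c1ccc(O)cc1` has not yet been run; it differs from compound 2 by hydroxy in place of dimethylamino on an aromatic carbon. Within the data shown here, only one measured step bears on this position: a 31-fold lower number from compound 1 to compound 2 (1.49 log units; beyond the scatter), which shows that a change at this aromatic carbon can move this assay by a large amount. That step went from hydrogen to dimethylamino, not to hydroxy, so its direction cannot be carried over directly. The removal of the dimethylamino is expected to undo part of that gain, giving a step of about a 9.5-fold higher number from compound 2 to compound 3 (0.98 log units; beyond the scatter) for compound 3. Compound 3 is therefore estimated at 3000000 nM, with a range of 600000 nM to 10000000 nM.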

Compound 3, half-maximal inhibitory concentration: 632000 nM
For compound 3 the middle estimate is 4.7-fold (0.68 log units) above the measured one; measured number inside the range.
By their numbers in this assay, from the lowest: compounds 2 and 3 (each within the scatter of the next); then compound 1.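

In this assay, hydroxy in place of dimethylamino on an aromatic carbon gives a 2.0-fold higher number from compound 2 to compound 3 (0.30 log units; within the scatter), so at this position the two groups cannot be told apart, despite their different heavy-atom and hydrogen-bond donor counts. Hydroxy in place of hydrogen gives a 15-fold lower number from compound 1 to compound 3 (1.19 log units; beyond the scatter), which shows that the large step at this carbon, para to a large group, is not confined to dimethylamino and appears with two different groups. Nothing available explains why these two groups land together. The compounds shown leave open whether a methyl or a chlorine at this carbon would also give a large step from compound 1, and whether a carboxylic acid would. They also leave open whether a longer chain on the nitrogen of the dimethylamino would shift the number.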